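Moving the two chlorines on the aryl ether of compound 2

The source may report more compounds than this note shows. Statements on the series, on what has been measured and on what is new or still open speak of the compounds shown alone.

Compound 2 `CCC(COc1c(Cl)cccc1Cl)OC(=O)NCc1ccccc1` stands at a limit of the assay: in an assay for inhibition of zeta-carotene desaturase, chloroplastic/chromoplastic (Capsicum annuum), using a Dixon plot, with a stated time of 8 h (on this read-out higher numbers stand for weaker inhibition and lower numbers for stronger inhibition), compound 2 gives > 100000 nM, a limit and not a number. Within the data shown here, its one measured neighbour, compound 1 `CCC(COc1cc(Cl)ccc1Cl)OC(=O)NCc1ccccc1`, sits at the same limit, since in this assay compound 1 gives > 100000 nM. Among the measured compounds shown here, the step that the two limits leave unreadable from compound 1 to compound 2 is therefore unreadable, and the only evidence on hand is the limit of > 100000 nM in this assay, at which 2 of the 2 values shown sit. Compound 3 `CCC(COc1cc(Cl)cc(Cl)c1)OC(=O)NCc1ccccc1` differs from compound 2 by 3,5-dichlorophenyl in place of 2,6-dichlorophenyl on an oxygen on a saturated carbon. For the measured compounds named here, the single measured step with the same kind of change, from one dichlorophenyl pattern to another on this oxygen, cannot be sized, so no direction can be read for the step into compound 3. Both compounds shown sit at the limit, and it is expected that compound 3 remains there, with the step that the limit leaves unreadable from compound 2 to compound 3 expected to lie within the scatter. Compound 3 is therefore expected to give about 150000 nM in this assay, estimated between 40000 nM and 600000 nM, most likely reported again only as a limit.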

Compound 3, half-maximal inhibitory concentration: > 100000 nM
Compound 3 ended at the assay's limit (the forecaster's own chance of this, stated with the estimate: 80%); the middle value is on the limit's open side.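

In this assay compound 3 gives > 100000 nM as a limit and not a number. Among these compounds, compound 1, compound 2 and compound 3 all stand at such a limit, so no step among them can be read. The compounds shown leave open whether any dichlorophenyl pattern on this oxygen gives a measurable inhibition.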